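The source may hold more compounds than are shown below. What is called first, only, known or untested is meant among the compounds shown, and "the series" means these compounds.

Measured so far:
Compound 1, `COc1ccc(-c2ccc3c(c2)oc(=O)n3C(=O)NCCCCc2ccccc2)cc1`: 67 nM
Compound 2, `O=C(NCCCCc1ccccc1)n1c(=O)oc2cc(Cl)ccc21`: 33 nM
Compound 3, `O=C(NCCCCc1ccccc1)n1c(=O)oc2cc(F)ccc21`: 31 nM

All three were tested in an assay on HEK293 cells for inhibition of acid ceramidase (Homo sapiens), with a stated time of 10 min; a higher number here means a weaker inhibitor, a lower number a stronger inhibitor. Compound 3 stands apart from compound 1 by a 2.2-fold lower number from compound 1 to compound 3 (0.33 log units; beyond the scatter), while the remaining step is only a 1.1-fold lower number from compound 2 to compound 3 (0.03 log units; within the scatter), so compounds 2 and 3 cannot be told apart. Compound 4, `O=C(NCCCCc1ccccc1)n1c(=O)oc2cc(Br)ccc21`, differs from compound 3 by bromo in place of fluoro on an aromatic carbon. For the measured compounds named here, the one measured step that bears on this swap of one halogen for another is a 1.1-fold lower number from compound 2 to compound 3 (0.03 log units; within the scatter), which stayed within the scatter; the exchange of a halogen for 4-methoxyphenyl moved the number by a 2.0-fold lower number from compound 1 to compound 2 (0.31 log units; beyond the scatter), but that is a different kind of change. For compound 4 the expected step is a 1.0-fold lower number from compound 3 to compound 4 (0.01 log units; within the scatter), leaving it close to where compound 3 lies. The estimate for compound 4 in this assay is 30 nM, with a range from 15 nM to 60 nM.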

Compound 4, half-maximal inhibitory concentration: 31 nM
Compound 4: the middle estimate sits 1.0-fold (0.01 log units) below what was measured; low and high end bracket the measured number.
By their numbers in this assay, from the lowest: compounds 3, 4 and 2 (each within the scatter of the next); then compound 1.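

Across the three halogens at this position on the six-membered aromatic ring, bromo in place of fluoro gives no change at the digits printed from compound 3 to compound 4 (within the scatter) and bromo in place of chloro gives a 1.1-fold lower number from compound 2 to compound 4 (0.03 log units; within the scatter) so fluoro, chloro and bromo cannot be told apart here. Bromo in place of 4-methoxyphenyl gives a 2.2-fold lower number from compound 1 to compound 4 (0.33 log units; beyond the scatter) and thus matches the step seen with the two smaller halogens. Nothing available explains why these three halogens read alike. Still open, going by these compounds, is how a plain hydrogen, an amine or a carboxylic acid at this position would compare.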